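Benzyl swap on the ring nitrogen of compound 1

This account rests on a few compounds, and the source may have more. Where it says the series, first, only, none or still open, it means among the compounds named here.

The series shares one core carrying a benzyl group on the ring nitrogen and an anilide on the exocyclic aryl ring. Compound 1 `C=C(Br)C(=O)Nc1ccc(/C=C2\SC(=O)N(Cc3cccc(F)c3)C2=O)cc1` gives 3200 nM in a functional assay on CCRF-CEM cells (Homo sapiens) for cytotoxicity, read by cell counting, with a stated time of 3 days (on this read-out lower numbers stand for stronger inhibition and higher numbers for weaker inhibition), the lowest of the two numbers in hand. Among the measured compounds shown here, compound 2 `Nc1ccc(/C=C2\SC(=O)N(Cc3cccc(F)c3)C2=O)cc1` gives 116000 nM in this assay, and a 36-fold higher number from compound 1 to compound 2 (1.56 log units; beyond the scatter) is the only pair in the set that differs in a single place. Compound 3 `Nc1cccc(/C=C2\SC(=O)N(Cc3ccccc3)C2=O)c1` gives > 250000 nM in this assay, which is a limit of the assay rather than a number (the limit of > 250000 nM in this assay, at which 1 of the 3 values shown sits). Compound 3 and compound 2 differ in two places, so their two values show no more than that both lie far from compound 1.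

Compound 4 `C=C(Br)C(=O)Nc1ccc(/C=C2\SC(=O)N(Cc3ccc(Cl)cc3)C2=O)cc1` differs from compound 1 by 4-chlorophenyl in place of 3-fluorophenyl on a saturated chain carbon bound to an amide-type nitrogen in a ring. For the measured compounds named here, no measured step in this assay touches the group on the saturated chain carbon bound to the amide-type nitrogen in the ring: the single step in hand concerns the (1-bromoethenyl)carbonyl on the aniline nitrogen, which compound 4 keeps. Going by the values given here, with no measured step bearing on the change, a step beyond the scatter is not expected in either direction. The step is estimated as no change at the digits printed from compound 1 to compound 4 (within the scatter), inside the usual scatter. Compound 4 is expected to give 3200 nM in this assay, with a range from 1000 nM to 10000 nM.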

Compound 4, half-maximal inhibitory concentration: 2800 nM
Compound 4: the middle estimate sits 1.1-fold (0.06 log units) above what was measured, within the range that was stated.
By their numbers in this assay, from the lowest: compounds 4 and 1 (each within the scatter of the next); then compound 2. At a limit, above all of these: compound 3.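

In this assay, among the compounds shown here, the exchange of 3-fluorobenzyl for 4-chlorobenzyl gives a 1.1-fold lower number from compound 1 to compound 4 (0.06 log units; within the scatter), the first measured step at the saturated chain carbon bound to the amide-type nitrogen in the ring; the earlier step concerned only the aniline nitrogen. With the (1-bromoethenyl)carbonyl kept in both compounds, this one change of aromatic substituent leaves the two values within the scatter of each other, so this pair shows this position tolerating a swap of the 3-fluorophenyl for the 4-chlorophenyl, unlike the large step seen on removing the (1-bromoethenyl)carbonyl. Nothing in hand gives a reason for this result.

From the compounds shown here alone, the step changes the halogen and its ring location together, so the contribution of each cannot be read alone, and it remains unknown whether the same holds for the free aniline of compound 2. Also open, going by these compounds, is how the number would respond to a more different group at this position, such as a phenyl ring carrying an amine or a carboxylic acid, or a longer chain in place of the benzyl group.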